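The compounds below may be only part of what the source reports. "The series", "measured", "known", "first", "only" and "open" are said of these compounds alone.

In a functional assay on MV4-11 cells (Homo sapiens) for cytotoxicity, read by MTT assay, with a stated time of 72 h (a higher number here means a weaker inhibitor, a lower number a stronger inhibitor), three compounds sharing a core have been measured, and none gives a number. Compound 1 `CCOC(=O)c1csc2nc(-c3cccc(NC(=O)c4ccco4)c3)cn12` reaches only a limit, > 20000 nM. Compound 2 `C=CC(=O)Nc1cccc(-c2cn3c(C(=O)OCC)csc3n2)c1` also reaches only a limit, > 20000 nM. Compound 3 `CCOC(=O)c1csc2nc(-c3ccc(NS(=O)(=O)c4ccc(C)cc4)cc3)cn12` likewise reaches only a limit, > 20000 nM, so its place in this assay is bounded on one side and not fixed.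

Compound 4 `CCOC(=O)c1csc2nc(-c3ccc(NC(=O)CCl)cc3)cn12` departs from compound 3 at a single place: (chloromethyl)carbonyl in place of (4-methylphenyl)sulfonyl on a nitrogen on an aromatic ring. Among the measured compounds shown here, one measured step bears on this change, and only loosely, since it belongs to another pair of compounds: a step that the two limits leave unreadable from compound 1 to compound 2. It has no readable size, so no magnitude can be carried over to the new exchange. The (chloromethyl)carbonyl group has not yet been tested in this set, which leaves the outcome open.

Weak inhibition is expected to persist for compound 4 because of the limit of > 20000 nM in this assay, at which 3 of the 3 values shown sit. Any readable change would be expected toward stronger inhibition, and the estimated step is an at least 1.3-fold lower number from compound 3 to compound 4 (0.12 log units; that floor lies within the scatter). Compound 4 is expected at 15000 nM, with an estimated range from 4000 nM to 30000 nM.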

Compound 4, half-maximal inhibitory concentration: 9070 nM
Compound 4: the middle estimate sits 1.7-fold (0.22 log units) above what was measured; the measured number falls inside the stated range.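

In this assay, the nitrogen on the aromatic ring proves to be a place where an exchange of group can be read: (chloromethyl)carbonyl in place of (4-methylphenyl)sulfonyl gives an at least 2.2-fold lower number from compound 3 to compound 4 (0.34 log units; beyond the scatter). Until now the only step between measured compounds could not be read, so no change in this set had shown a size or a direction. Compound 4 is the one compound shown that comes off the limit, while the other three remain there: the limit of > 20000 nM in this assay, at which 3 of the 4 values shown sit.

The step is only a floor, since compound 3 holds a limit and not a number, and the exchange swaps a whole ring-bearing sulfonyl group for a small chlorine-bearing carbonyl group, so the compounds shown cannot say which part of the change carries the step. Going by these compounds, whether the chlorine itself matters remains open, and a plain acetyl group or a longer chlorinated chain on the same nitrogen, read in this assay, would bear on that question.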